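Methoxy for fluoro on a furan-linked amidine

This account rests on a few compounds, and the source may have more. Where it says the series, first, only, none or still open, it means among the compounds named here.

Measured compounds:
Compound 1 `N=C(N)c1ccc(-c2ccc(-c3ccc(F)cc3)o2)o1`: 1360 nM
Compound 2 `N=C(N)c1ccc(-c2ccc(-c3ccc4ccccc4c3)s2)s1`: 1960 nM

In a functional assay on NCI-H522 cells (Homo sapiens) for inhibition, read by sulforhodamine B assay, with a stated time of 48 h (a higher number here means a weaker inhibitor of growth, a lower number a stronger inhibitor of growth), compound 1 gives 1360 nM, the lowest of the two numbers; compound 2 gives 1960 nM, which lies within the scatter of that figure, so the two cannot be ordered. Compound 3 `COc1ccc(-c2ccc(-c3ccc(C(=N)N)o3)o2)cc1` differs from compound 1 by methoxy in place of fluoro on an aromatic carbon. Among the compounds with values here, no measured pair shows this exchange, so the step from compound 1 to compound 3 is expected to be small, with no direction beyond the scatter: a 1.1-fold higher number from compound 1 to compound 3 (0.04 log units; within the scatter). Compound 3 is therefore estimated at 1500 nM in this assay, within 500 nM to 4500 nM.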

Compound 3, concentration for 50% growth inhibition: 1090 nM
Beside the measured number, compound 3's estimate is 1.4-fold (0.14 log units) above it; low and high end bracket the measured number.
By their numbers in this assay, from the lowest: compounds 3, 1 and 2 (each within the scatter of the next).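

In this assay the exchange of methoxy for fluoro, on an aromatic carbon para to a large group, gives a 1.2-fold lower number from compound 1 to compound 3 (0.10 log units; within the scatter) and so stays within the scatter. This position therefore accepts two heavy atoms in place of one, and a hydrogen-bond acceptor where there was none, with no readable change in the number. Nothing available bears on why the number holds. From the compounds shown here alone, whether an amine, a carboxylic acid or a longer chain such as ethoxy at this position would move the number beyond the scatter stays open. Also open, going by these compounds, is whether the same exchange behaves alike on another core.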